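Swapping the aryl arm: from compound 3 to compound 4

The compounds below may be only part of what the source reports. "The series", "measured", "known", "first", "only" and "open" are said of these compounds alone.

Compound 1 `COc1ncc(-c2ccccc2)cc1[C@@H](c1ccccc1)[C@@](O)(CCN(C)C)c1cccc2ccccc12` and compound 2 `COc1ncc(-c2ccccc2)cc1[C@@H](c1ccccc1)[C@@](O)(CCN(C)C)c1cccc(F)c1F` share a core with compound 3 `COc1nc(-c2ccccc2F)ccc1[C@@H](c1ccccc1)[C@@](O)(CCN(C)C)c1cccc2ccccc12` and compound 4 `COc1nc(-c2ccc(OC(F)(F)F)cc2)ccc1[C@@H](c1ccccc1)[C@@](O)(CCN(C)C)c1cccc2ccccc12`. For the measured compounds named here, in a toxicity assay on HeLa cells (Homo sapiens) for cytotoxicity (on this read-out higher numbers stand for lower toxicity in this test and lower numbers for higher toxicity in this test), compound 1 gives 30.4 ug/mL, and compound 2 gives 28.1 ug/mL; the one measured step, a 1.1-fold lower number from compound 1 to compound 2 (0.03 log units; within the scatter), lies within the scatter. In this assay compound 3 gives "nd" (no result reported), that is, no result, so it stands on no number at all. The change to compound 4 is 4-(trifluoromethoxy)phenyl in place of 2-fluorophenyl on an aromatic carbon. Going by the values given here, no measured step touches this position, so nothing shows how it might shift the read-out, and the only anchors are the two measured values, both near one level. Compound 4 is therefore expected to give roughly 28 ug/mL, with a range from 10 ug/mL to 70 ug/mL, and no direction beyond the scatter is expected.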

Compound 4, half-maximal cytotoxic concentration: > 64 ug/mL
Compound 4: a limit, no number; the forecaster's own chance of this, stated with the estimate: 15%; middle value at least 2.2-fold (0.35 log units) away from the limit.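

In this assay compound 4 gives > 64 ug/mL, which is a limit and not a number. For the compounds shown here, compound 3 has no result, so no step between compound 3 and compound 4 can be read. The compounds shown leave open how 4-(trifluoromethoxy)phenyl and 2-fluorophenyl compare on this read-out.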